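Four stereoisomers and a single inhibition read-out

The source may hold more compounds than are shown below. What is called first, only, known or untested is meant among the compounds shown, and "the series" means these compounds.

Of the compounds shown here, three measured so far share one set of atoms and bonds and differ only in how their configuration is drawn. Compound 1 `CC(C)(C)OC(=O)/C=C\NC(=O)[C@H](O)C(C)(C)CO` gives -9% in an ADME assay on HEK293 cells (Homo sapiens) for inhibition, read by CellTiter-Glo, with a stated time of 96 h, tested at 100 uM; a higher number here means more inhibition at the concentration tested (going by the name of the read-out), a lower number less inhibition. Compound 2 `CC(C)(C)OC(=O)/C=C/NC(=O)[C@@H](O)C(C)(C)CO` gives -8% in this assay, and compound 3 `CC(C)(C)OC(=O)/C=C/NC(=O)[C@H](O)C(C)(C)CO` gives -1%. Compound 3 stands at the largest of the three numbers, though its gaps to compound 2 and to compound 1 both lie within the scatter. Compounds 1 and 2 differ only in configuration (the fact that compounds 1 and 2 differ only in the configuration as drawn), as do compounds 1 and 3 the fact that compounds 1 and 3 differ only in the configuration as drawn and compounds 2 and 3 (the fact that compounds 2 and 3 differ only in the configuration as drawn). The step of a number 8 percentage points higher from compound 1 to compound 3 (within the scatter) follows a change at the double bond alone, the step of a number 7 percentage points higher from compound 2 to compound 3 (within the scatter) a change at the stereocentre alone, and the step of a number 1 percentage points higher from compound 1 to compound 2 (within the scatter) a change at both; each stays within the scatter.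

Compound 4 `CC(C)(C)OC(=O)/C=C\NC(=O)[C@@H](O)C(C)(C)CO` is now to be measured. the two compounds have the same atoms and bonds and differ only in configuration as drawn: 2 of 2 stereo elements differ; a stereocentre at a saturated chain carbon is drawn R in compound 3 and S in compound 4; a double bond is drawn E in compound 3 and Z in compound 4 Since every measured change of configuration, single or double, left the read-out within the scatter, no step beyond the scatter is expected here, a number 5 percentage points lower from compound 3 to compound 4 (within the scatter). Compound 4 is therefore estimated at -6%, between -16% and 4%.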

Compound 4, a percentage reported as inhibition, at one concentration (the size of the read-out at that concentration, not a potency): -11%
Compound 4: middle estimate off by 5 percentage points, on the high side; low and high end bracket the measured number.
By their numbers in this assay, from the lowest: compounds 4, 1, 2 and 3 (each within the scatter of the next).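

With compound 4 in place, all four stereoisomers can be compared in this assay, and each element can now be read alone from a second pair. The change at the stereocentre with the double bond drawn Z gives a number 2 percentage points lower from compound 1 to compound 4 (within the scatter), and the change at the double bond with the stereocentre drawn S gives a number 3 percentage points lower from compound 2 to compound 4 (within the scatter). Changing both elements together gives a number 10 percentage points lower from compound 3 to compound 4 (within the scatter), so no change of configuration, alone or combined, takes the read-out beyond the scatter, and the structural relation of this last pair is simply this: the fact that compounds 3 and 4 differ only in the configuration as drawn

The four compounds share all their atoms and bonds, so they leave open whether a carboxylic acid in place of the tert-butyl ester, or an amine in place of a hydroxyl group, would shift the read-out beyond the scatter. How any of these compounds behaves at other concentrations also stays open.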